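The compounds below may be only part of what the source reports. "The series", "measured", "known", "first", "only" and "open" are said of these compounds alone.

Measured in a functional assay on SF-295 cells (Homo sapiens) for antiproliferative activity, read by sulforhodamine B assay, with a stated time of 72 h; a lower number here means a stronger inhibitor, a higher number a weaker inhibitor:
- compound 1 `O=C1CS/C(=N/Nc2nncc3ccccc23)N1c1ccccc1`: 4.6 nM
- compound 2 `CCN1C(=O)CS/C1=N/Nc1nncc2ccccc12`: 3.5 nM
- compound 3 `Cc1cc(C)nc(NS(=O)(=O)c2ccc(Nc3nncc4ccccc34)cc2)n1`: 0.56 nM

Compound 2 lies within the scatter of compound 1, and these two form the upper end of the three numbers. Compound 3 has a lower number than compound 2, beyond the scatter.

Next is compound 4 `O=C1CS/C(=N/Nc2nncc3ccccc23)N1`, with hydrogen in place of ethyl on an amide-type nitrogen in a ring. For the measured compounds named here, the only measured step at this nitrogen is a 1.3-fold lower number from compound 1 to compound 2 (0.12 log units; within the scatter), and no measured compound carries hydrogen there. On that single step, no change beyond the scatter is expected in this assay. The expected step is a 1.1-fold higher number from compound 2 to compound 4 (0.06 log units; within the scatter). For compound 4 the estimated value is 4 nM, with an expected range of 1.5 nM to 11 nM.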

Compound 4, half-maximal inhibitory concentration: 2.4 nM
Compound 4: middle estimate off by 1.7-fold (0.22 log units), on the high side; measured number inside the range.
By their numbers in this assay, from the lowest: compound 3; then compounds 4, 2 and 1 (each within the scatter of the next).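

In this assay, the step of a 1.5-fold lower number from compound 2 to compound 4 (0.16 log units; within the scatter) and the step of a 1.9-fold lower number from compound 1 to compound 4 (0.28 log units; within the scatter) both stay within the scatter. Hydrogen, ethyl and phenyl on this amide-type nitrogen therefore give numbers that compound 1, compound 2 and compound 4 do not separate, and neither carbon group is needed to keep the number in this range. Nothing available explains this flat result. Still open, going by these compounds, is whether a different kind of group on this nitrogen, such as a longer chain ending in an amine or a carboxylic acid, would move the number beyond the scatter.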